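Pyridine amidrazone thiosemicarbazides: ring size at the thiocarbonyl

The compounds below may be only part of what the source reports. "The series", "measured", "known", "first", "only" and "open" are said of these compounds alone.

Measured so far:
compound 1 `N/C(=N\NC(=S)N1CCCC1)c1ccc(F)cn1` — 50.7%
compound 2 `N/C(=N\NC(=S)N1CCCCC1)c1ccccn1` — 24.4%

Two compounds of the series have been run in a functional assay on A-431 cells (Homo sapiens) for cytotoxicity, read by MTT assay, with a stated time of 72 h, tested at 1 uM; a lower number here means less inhibition of growth, a higher number more inhibition of growth at the concentration tested. Compound 1 gives 50.7%, and compound 2 gives 24.4%. Compound 2 thus stands lowest of the two numbers; its nearest neighbour is compound 1, whose value is higher by a margin beyond the scatter. The two compounds differ in more than one place, so the gap cannot be assigned to either change alone; it is only what the two values show.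

Compound 3 `N/C(=N\NC(=S)N1CCCC1)c1ccccn1` has not been measured. Relative to compound 2, it carries pyrrolidin-1-yl in place of piperidin-1-yl on a thiocarbonyl carbon. For the measured compounds named here, no measured pair isolates this change. Compound 1, which also carries the pyrrolidin-1-yl group, shows the higher of the two numbers, so a moderate rise from compound 2 to compound 3 in this assay is expected rather than no change, though the direction rests on a single, confounded comparison. The expected step from compound 2 to compound 3 is a number 12.6 percentage points higher from compound 2 to compound 3 (beyond the scatter). For compound 3 in this assay the estimate is 37%, within a range of 20% to 56%.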

Compound 3, percent growth inhibition at one concentration: 39.8%
Compound 3: the middle estimate sits 2.8 percentage points below what was measured, within the range that was stated.
By their numbers in this assay, from the lowest: compound 2; then compound 3; then compound 1.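

In this assay, the ring size on the thiocarbonyl carbon can now be read on its own: pyrrolidin-1-yl in place of piperidin-1-yl gives a number 15.4 percentage points higher from compound 2 to compound 3 (beyond the scatter). Compound 3 also isolates the other change, as hydrogen in place of fluoro on an aromatic carbon gives a number 10.9 percentage points lower from compound 1 to compound 3 (beyond the scatter), so each of the two structural changes has its own step beyond the scatter, and the fluoro group and the five-membered ring are each tied to the higher number in their own pair. The compounds shown give no measurement that accounts for either step.

On these data alone, each step rests on a single pair, so it remains open whether the gain from pyrrolidin-1-yl over piperidin-1-yl also holds on the fluoro-bearing core, which would need the piperidin-1-yl compound with that fluoro group as a partner for compound 1. Also open, as far as these compounds go, is how far the trend in ring size extends on the thiocarbonyl carbon, for instance to azetidin-1-yl, azepan-1-yl or morpholin-4-yl, and whether chloro or methoxy on the aromatic carbon would behave as fluoro does.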